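The compounds below may be only part of what the source reports. "The series", "measured", "known", "first", "only" and "open" are said of these compounds alone.

Compound 1, `Cc1cn([C@@H]2O[C@H](CO[Si](C)(C)C(C)(C)C)[C@@]3(OS(=O)(=O)C=C3NC(=O)NC(=O)c3ccccc3)[C@H]2O[Si](C)(C)C(C)(C)C)c(=O)n(C)c1=O`, gives >= 80000 nM in an ADME assay on HEL cells (Homo sapiens) for cytotoxicity, with a stated time of 3 days (on this read-out higher numbers stand for lower toxicity in this test and lower numbers for higher toxicity in this test), which is a limit of the assay rather than a number.
Compound 2, `Cc1cn([C@@H]2O[C@H](CO[Si](C)(C)C(C)(C)C)[C@@]3(OS(=O)(=O)C=C3NC(=O)NC(=O)c3ccccc3)[C@H]2O[Si](C)(C)C(C)(C)C(C)C)c(=O)n(C)c1=O`, gives >= 100000 nM in this assay, again a limit.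
Compound 3, `Cc1cn([C@@H]2O[C@H](COCc3ccccc3)[C@@]3(OS(=O)(=O)C=C3NC(=O)NC(=O)c3ccccc3)[C@H]2O[Si](C)(C)C(C)(C)C)c(=O)n(C)c1=O`, gives > 50000 nM in this assay, also a limit.

Compound 1 thus stands only at a limit in this assay, and the two other measured compounds sit at limits as well (the limit of >= 80000 nM in this assay, at which 1 of the 3 values shown sits, (the limit of >= 100000 nM in this assay, at which 1 of the 3 values shown sits), (the limit of > 50000 nM in this assay, at which 1 of the 3 values shown sits)). Neither measured step can be read: the change a step that the two limits leave unreadable from compound 1 to compound 2 and the change a step that the two limits leave unreadable from compound 1 to compound 3 both lie between limits, so their sizes are not known. Both of those changes, however, concern the silicon-bearing groups on the sugar oxygens, not the part of compound 1 that is altered next.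

The next compound is compound 4, `Cc1cn([C@@H]2O[C@H](CO[Si](C)(C)C(C)(C)C)[C@@]3(OS(=O)(=O)C=C3NC(N)=O)[C@H]2O[Si](C)(C)C(C)(C)C)c(=O)n(C)c1=O`, which differs from compound 1 by hydrogen in place of benzoyl on an amide-type nitrogen. Among the compounds with values here, no measured step touches this position, so nothing in the three values read so far speaks for or against a change in cytotoxicity here. With every measured compound at a limit, the step of a number no higher from compound 1 to compound 4 (the limit leaves the size open) is expected to show no change beyond the scatter. Compound 4 is accordingly estimated to give 80000 nM in this assay, within a range from 35000 nM to 200000 nM, most likely again reported as a limit.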

Compound 4, minimum cytotoxic concentration: 16000 nM
For compound 4 the middle estimate is 5.0-fold (0.70 log units) above the measured one; the whole stated range lies above it.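

In this assay, the change from (benzoylcarbamoyl)amino to ureido gives an at least 5.0-fold lower number from compound 1 to compound 4 (0.69 log units; beyond the scatter). This is the first change among the compounds shown whose effect on the read-out can be seen beyond the scatter, and it shows that this position, unlike the silicon-bearing groups so far, can be tied to a readable shift towards higher toxicity in this test. The full size of the step stays open, because compound 1 stands at a limit: the limit of >= 80000 nM in this assay, at which 1 of the 4 values shown sits.

The compounds shown leave open whether the loss of the aromatic ring or of the whole benzoyl goes with the lower number, a question that an acetyl on the same amide-type nitrogen would address. Going by these compounds, the steps from compound 1 to compound 2 and to compound 3 lie between limits and cannot be read, so it also stays open whether the silicon-bearing groups matter in this assay, or whether removing benzoyl would give a similar step with the benzyl group of compound 3 on the sugar oxygen.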